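The source may hold more compounds than are shown below. What is called first, only, known or untested is meant among the compounds shown, and "the series" means these compounds.

Compound 1 `COC(=O)C[C@H](NC(=O)OC(C)(C)C)C(=O)N(Cc1ccc(F)cc1)C1(C(=O)NCc2ccccc2)CCN(Cc2ccccc2)CC1` is known in an ADME assay on MDCK cells (Canis lupus familiaris) for cytotoxicity, read by microscopy, with a stated time of 72 h (a higher number here means that more compound is tolerated, a lower number that less compound is tolerated), only as a limit, where compound 1 gives > 100000 nM. Compound 2 `COC(=O)C[C@H](NC(=O)OC(C)(C)C)C(=O)N(Cc1ccc(F)cc1)C1(C(=O)NCc2ccccc2)CCN(C)CC1` gives 17000 nM in this assay, and compound 3 `COC(=O)C[C@H](NC(=O)OC(C)(C)C)C(=O)N(Cc1ccc(F)cc1)C1(C(=O)NCc2ccccc2)CCN(c2ccccc2)CC1` gives 20000 nM. Both steps away from compound 1 lower the number, an at least 5.8-fold lower number from compound 1 to compound 2 (0.76 log units; beyond the scatter) and an at least 5.0-fold lower number from compound 1 to compound 3 (0.69 log units; beyond the scatter), while between them a 1.2-fold higher number from compound 2 to compound 3 (0.07 log units; within the scatter). Those changes sit on the amine nitrogen in the ring; compound 4 `COC(=O)C[C@H](NC(=O)OC(C)(C)C)C(=O)N(Cc1ccc(F)cc1)C1(C(=O)NCS(=O)(=O)c2ccc(C)cc2)CCN(Cc2ccccc2)CC1` differs from compound 1 elsewhere, ((4-methylphenyl)sulfonyl in place of phenyl on a saturated chain carbon bound to an amide-type nitrogen). Within the data shown here, no measured step covers that position, so the size of any step in this assay is open; since compound 1 stands at the limit of > 100000 nM in this assay, at which 1 of the 3 values shown sits, only a lower number or another limit can appear. The step expected is an at least 2.0-fold lower number from compound 1 to compound 4 (0.30 log units; that floor lies within the scatter). Compound 4 is estimated at 50000 nM, within 15000 nM to 100000 nM.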

Compound 4, minimum cytotoxic concentration: 4000 nM
Compound 4: middle estimate off by 13-fold (1.10 log units), on the high side; measured number below the stated range.
By their numbers in this assay, from the lowest: compound 4; then compounds 2 and 3 (each within the scatter of the next). At a limit, above all of these: compound 1.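

In this assay, the place on a saturated chain carbon bound to an amide-type nitrogen proves sensitive: (4-methylphenyl)sulfonyl in place of phenyl gives an at least 25-fold lower number from compound 1 to compound 4 (1.39 log units; beyond the scatter). Tolerance in the series therefore does not turn on the amine nitrogen in the ring alone. The true size of this step stays unknown, since it starts from a limit: the limit of > 100000 nM in this assay, at which 1 of the 4 values shown sits.

The compounds shown do not separate the sulfonyl from the 4-methylphenyl part of the new group. Open too, on these data alone, are how a carboxylic acid or a longer chain would read at this place, and how this change reads with methyl or phenyl on the ring amine nitrogen.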